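A few compounds are considered here, and "the series" means these few. Any claim that something is new, unique, unknown or untested is made for them only; others in the source may bear on it.

Compound 2 `COc1ccc(COc2cc(O)c3c(=O)cc(C)oc3c2[C@H]2CCN(C)C[C@H]2O)cc1` gives the lowest of the three numbers in a functional assay on Caco-2 cells (Homo sapiens) for inhibition, read by MTT assay, with a stated time of 48 h, tested at 10 uM (a lower number here means less inhibition of growth, a higher number more inhibition of growth at the concentration tested), with compound 2 at 8%. Compound 1 `Cc1cc(=O)c2c(O)cc(OCc3ccccc3)c([C@H]3CCN(C)C[C@H]3O)c2o1` lies nearest, with compound 1 at 18%, a step of a number 10 percentage points lower from compound 1 to compound 2 (within the scatter). Compound 3 `Cc1cc(=O)c2c(O)cc(OCc3ccccc3Br)c([C@H]3CCN(C)C[C@H]3O)c2o1` stands furthest away, with compound 3 at 35%, a step of a number 27 percentage points higher from compound 2 to compound 3 (beyond the scatter). Compound 4 `Cc1cc(=O)c2c(O)cc(OC/C=C/c3ccccc3)c([C@H]3CCN(C)C[C@H]3O)c2o1` differs from compound 2 in one place: 2-phenylethenyl in place of 4-methoxyphenyl on a saturated chain carbon bound to an oxygen on an aromatic ring. The step from compound 2 to compound 3 also replaced the 4-methoxyphenyl group and the number rose beyond the scatter, while the step from compound 1 to compound 2 stayed within it. A modest rise is therefore expected for compound 4, a number 12 percentage points higher from compound 2 to compound 4 (beyond the scatter). Compound 4 is estimated at 20%, between 8% and 35%.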

Compound 4, percent growth inhibition at one concentration: 9%
Beside the measured number, compound 4's estimate is 11 percentage points above it, within the range that was stated.
By their numbers in this assay, from the lowest: compounds 2, 4 and 1 (each within the scatter of the next); then compound 3.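

In this assay, 2-phenylethenyl in place of 4-methoxyphenyl shows no real difference at this position (a number 1 percentage points higher from compound 2 to compound 4 (within the scatter)). The same reading holds for 2-phenylethenyl in place of phenyl (a number 9 percentage points lower from compound 1 to compound 4 (within the scatter)). Against 2-bromophenyl the picture differs (a number 26 percentage points lower from compound 3 to compound 4 (beyond the scatter)), so the higher number of compound 3 is not shared by every replacement of the phenyl group here.

No measurement at hand explains this result. On these data alone, whether an amine or a carboxylic acid on the phenyl ring, or a longer chain in place of 2-phenylethenyl, would move the number stays open.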